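The compounds below may be only part of what the source reports. "The series", "measured", "known", "first", "only" and "open" are said of these compounds alone.

Of the compounds shown here, three on the shared core have been measured in an assay on HEK293 cells for inhibition of 17-beta-hydroxysteroid dehydrogenase type 2 (Homo sapiens), read by scintillation counting, with a stated time of 10 min, in the presence of a further agent that is not named here; on this read-out lower numbers stand for stronger inhibition and higher numbers for weaker inhibition. Compound 1 `CC(C)(C)c1ccc(S(=O)(=O)Nc2cc(Cl)c(Cl)cc2N)cc1` gives 4650 nM. Compound 2 `CC(C)(C)c1ccc(S(=O)(=O)Nc2ccccc2O)cc1` gives 1230 nM, the lowest of the three numbers. Compound 3 `Cc1ccc(NS(=O)(=O)c2ccc(C(C)(C)C)cc2)c(O)c1` gives 4400 nM. Among the compounds with values here, the only step between compounds that differ in one place, a 3.6-fold higher number from compound 2 to compound 3 (0.55 log units; beyond the scatter), shows that adding a methyl group on an aromatic carbon moves the number beyond the scatter, though only modestly. Compound 4 `CC(C)(C)c1ccc(S(=O)(=O)Nc2cc(-c3ccccc3)ccc2O)cc1` differs from compound 2 by phenyl in place of hydrogen on an aromatic carbon. Within the data shown here, no measured step involves a phenyl group, and the measured step concerns a different group at a different place, so it bears on the question only loosely: it shows that a substituent on this ring can shift the number beyond the scatter without changing it greatly. The expectation for compound 4 is therefore a step of about a 1.6-fold higher number from compound 2 to compound 4 (0.21 log units; within the scatter), with no confident direction and a wide range. Compound 4 is estimated at 2000 nM in this assay, between 500 nM and 8000 nM.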

Compound 4, half-maximal inhibitory concentration: 1250 nM
Compound 4: middle estimate off by 1.6-fold (0.20 log units), on the high side, within the range that was stated.
By their numbers in this assay, from the lowest: compounds 2 and 4 (each within the scatter of the next); then compounds 3 and 1 (each within the scatter of the next).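

In this assay the new step is a 1.0-fold higher number from compound 2 to compound 4 (0.01 log units; within the scatter) and so phenyl in place of hydrogen on this aromatic carbon, para to a hydroxy group and meta to a large group, is tolerated within the scatter. Within the data shown here, the earlier compounds could not show this: their only step, a 3.6-fold higher number from compound 2 to compound 3 (0.55 log units; beyond the scatter), concerns a methyl group at a different place and lies beyond the scatter. No evidence is at hand that bears on this result.

As far as these compounds go, it remains open whether a smaller group at this same place, such as methyl or chlorine, would also stay within the scatter. Also open, from the compounds shown here alone, is whether an amine or a carboxylic acid carried on the added phenyl would move the number beyond the scatter.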